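Tert-Butyl in Place of Methyl on Compound 2

The source may hold more compounds than are shown below. What is called first, only, known or untested is meant among the compounds shown, and "the series" means these compounds.

Compound 1 `COC(=O)C1=C(C)NC(=O)NC1c1ccoc1`: 42%
Compound 2 `COC(=O)C1=C(C)NC(=O)NC1c1cccs1`: 19%

In an assay on membranes from HEK293 cells for displacement of a labelled ligand from adenosine receptor A2b (Homo sapiens), read by scintillation counting, with a stated time of 30 min, tested at 1 uM (on this read-out higher numbers stand for more inhibition at the one concentration tested (going by the name of the read-out) and lower numbers for less inhibition), compound 1 gives 42%, while compound 2 gives 19%. Compound 2 stands lowest of the two numbers, set apart by a number 23 percentage points lower from compound 1 to compound 2 (beyond the scatter). Compound 3 `CC1=C(C(=O)OC(C)(C)C)C(c2cccs2)NC(=O)N1` differs from compound 2 by tert-butyl in place of methyl on an oxygen next to a carbonyl group. Among the compounds with values here, the single measured step puts thiophen-2-yl in place of furan-3-yl on a saturated ring carbon and does not touch the oxygen next to a carbonyl group, so no measured step bears on this change. The step of a number 1 percentage points higher from compound 2 to compound 3 (within the scatter) is therefore expected to stay within the scatter. Compound 3 is estimated at 20%, between 3% and 40%.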

Compound 3, a percentage reported as inhibition, at one concentration (the size of the read-out at that concentration, not a potency): 38%
Compound 3: middle estimate off by 18 percentage points, on the low side, within the range that was stated.
By their numbers in this assay, from the lowest: compound 2; then compounds 3 and 1 (each within the scatter of the next).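

In this assay, tert-butyl in place of methyl on an oxygen next to a carbonyl group gives a number 19 percentage points higher from compound 2 to compound 3 (beyond the scatter). This shows that the oxygen, which the earlier step left untouched, is also a place where a single change moves the number beyond the scatter, here upward with thiophen-2-yl held constant. Nothing available explains this rise. Going by these compounds, whether ethyl or isopropyl on the same oxygen, or a carboxylic acid in place of the whole group, would give a similar number remains open. So does whether tert-butyl gives a similar step alongside furan-3-yl.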